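Fluoro in Place of Methoxy on Compound 1

The source may hold more compounds than are shown below. What is called first, only, known or untested is meant among the compounds shown, and "the series" means these compounds.

In a functional assay on HeLa cells (Homo sapiens) for cytotoxicity, read by MTT assay, with a stated time of 72 h (a lower number here means a stronger inhibitor, a higher number a weaker inhibitor), compound 1 (`COc1ccc(Nc2ccc3ccccc3n2)cc1`) gives 51000 nM as its half-maximal inhibitory concentration. Compound 3 (`COc1ccc(Nc2cc(-c3ccc(C)cc3)ccn2)cc1`) gives 43000 nM and that number lies within the scatter of compound 1, so the two cannot be told apart. Compound 2 (`COc1ccc(Nc2cc(-c3cccc(C(F)(F)F)c3)ccn2)cc1`) gives 140000 nM and that number is higher than that of compound 1 by more than the scatter, which makes compound 2 the weaker inhibitor of that pair. Compound 1 therefore stands level with compound 3, with compound 2 apart from both.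

The next structure, compound 4 (`Fc1ccc(Nc2ccc3ccccc3n2)cc1`), keeps the core of compound 1 but has fluoro in place of methoxy on an aromatic carbon, para to a large group (fluoro in place of methoxy on an aromatic carbon). Among the compounds with values here, no two measured compounds differ in just one place, so the effect of this swap has no direct precedent here. The small size of the change points to a modest shift, although compound 2 shows that these structures can move beyond the scatter. The expected step of a 1.2-fold higher number from compound 1 to compound 4 (0.07 log units; within the scatter) is slight, upward and within the scatter. In this assay compound 4 is estimated at 60000 nM with 25000 nM to 130000 nM as the expected range of the measurement.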

Compound 4, half-maximal inhibitory concentration: 33000 nM
Compound 4: middle estimate off by 1.8-fold (0.26 log units), on the high side; measured number inside the range.
By their numbers in this assay, from the lowest: compounds 4, 3 and 1 (each within the scatter of the next); then compound 2.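

The swap gives a 1.5-fold lower number from compound 1 to compound 4 (0.19 log units; within the scatter) in this assay, so for this pair the two groups cannot be told apart on this aromatic carbon, para to a large group. Within the data shown here, this is the first direct comparison at this position, and it shows that methoxy, with 2 heavy atoms and 1 hydrogen-bond acceptor, can give way to fluoro, with 1 heavy atom and 0 hydrogen-bond acceptors, without a change that can be read in these numbers. Nothing shown here bears on how either group acts on the cells, so the result stands as an observation without an explanation.

On these data alone, one swap between two groups says little about the position as a whole, and it remains open whether an amine, a carboxylic acid or a longer chain on the same carbon would stay within the scatter of compound 1 or move clearly away from it. As far as these compounds go, it is also open whether fluoro in place of methoxy would give a similar result on compound 3, whose core differs from that of compound 1.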